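Fluorine on the phenyl ring of an aminopyrrolidine indazole

The source may report more compounds than this note shows. Statements on the series, on what has been measured and on what is new or still open speak of the compounds shown alone.

Three compounds share a core carrying a pyrrolidine amine, and all are measured in an assay on HEK293 cells for displacement of a labelled ligand from tyrosine-protein kinase receptor UFO (Homo sapiens), read by NanoBRET, with a stated time of 2 h; a higher number here means a weaker inhibitor, a lower number a stronger inhibitor. Compound 1 `Cn1cc(-c2n[nH]c3ccc(NC4CCNC4)cc23)cn1` has no single number; for compound 1 this assay reports "not determined" (no result reported). Compound 2 `Cn1cc(-c2n[nH]c3ccc(N[C@@H]4CCNC4)cc23)cn1` differs from compound 1 only in that (the fact that one of compounds 1 and 2 is drawn with a defined configuration and the other without, at the place where they differ); in this assay compound 2 gives 20700 nM. Among the measured compounds shown here, compound 3 `Clc1cc2[nH]nc(-c3cnn(-c4ccccc4)c3)c2cc1N[C@@H]1CCNC1` carries a chloro group and a phenyl on the pyrazole, and in this assay compound 3 gives 668 nM, the lowest of the two numbers known, well beyond the scatter from compound 2.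

Compound 4 `Fc1ccc(-n2cc(-c3n[nH]c4cc(Cl)c(N[C@@H]5CCNC5)cc34)cn2)cc1` is built from compound 3 by a single change: fluoro in place of hydrogen on an aromatic carbon. For the measured compounds named here, no measured pair here shows what such a swap does. The change adds only one small atom at the far edge of the molecule, so the expectation is a step from compound 3 to compound 4 of a 1.1-fold lower number from compound 3 to compound 4 (0.05 log units; within the scatter), that is, no difference beyond the scatter. Compound 4 is therefore estimated to give 600 nM in this assay, expected between 200 nM and 2000 nM.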

Compound 4, half-maximal inhibitory concentration: 684 nM
The estimate for compound 4 lay 1.1-fold (0.06 log units) below the measured number; measured number inside the range.
By their numbers in this assay, from the lowest: compounds 3 and 4 (each within the scatter of the next); then compound 2.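

Among the compounds shown here, this is the first comparison that changes only one place, phenyl to 4-fluorophenyl, and in this assay it comes to a 1.0-fold higher number from compound 3 to compound 4 (0.01 log units; within the scatter). Compound 3 and compound 4 therefore cannot be told apart in this measurement, so a fluoro can sit on this six-membered aromatic ring, para to a large group, with the number staying within the scatter. Nothing measured here offers a reason for this outcome. On these data alone, whether a different group at the same place, such as methoxy, an amine or a carboxylic acid, would also leave the number within the scatter remains open. Compound 2 and compound 3 differ in more than one place, so what the chloro group and the phenyl on the pyrazole each contribute also stays unresolved.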